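The compounds below may be only part of what the source reports. "The series", "measured", "known", "first", "only" and "open" are said of these compounds alone.

Compound 1 `COc1cc(-n2cccc2C(=O)N2CCCCC2)ccc1Nc1ncc(Cl)c(Nc2ccccc2NS(C)(=O)=O)n1` carries an amide whose nitrogen is part of a piperidine ring. In a functional assay on A549 cells (Homo sapiens) for antiproliferative activity, read by MTT assay, with a stated time of 72 h (a lower number here means a stronger inhibitor, a higher number a weaker inhibitor), compound 1 gives > 10000 nM, which is a limit of the measurement rather than a number. Compound 2 `COc1cc(-n2cccc2C(=O)NCCO)ccc1Nc1ncc(Cl)c(Nc2ccccc2NS(C)(=O)=O)n1` shares the same core but bears a (2-hydroxyethyl)amino group on that carbonyl carbon. In this assay compound 2 gives > 10000 nM, again only a limit. Compound 3 `COc1cc(-n2cccc2C(=O)N(C)C)ccc1Nc1ncc(Cl)c(Nc2ccccc2NS(C)(=O)=O)n1` places a dimethylamino group on the carbonyl carbon instead. In this assay compound 3 gives > 10000 nM, also a limit. As a result the steps a step that the two limits leave unreadable from compound 1 to compound 2, a step that the two limits leave unreadable from compound 1 to compound 3 and a step that the two limits leave unreadable from compound 2 to compound 3 cannot be sized, since all three compounds sit at the limit of > 10000 nM in this assay, at which 3 of the 3 values shown sit.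

Compound 4 `COc1cc(-n2cccc2C(=O)N2CC(O)C2)ccc1Nc1ncc(Cl)c(Nc2ccccc2NS(C)(=O)=O)n1` alters the same place: 3-hydroxyazetidin-1-yl in place of piperidin-1-yl on a carbonyl carbon. The three measured steps all concern exchanges of the group on this carbonyl carbon, and none of them yielded a readable number on either side. Among the measured compounds shown here, a further exchange at this position is therefore expected to leave compound 4 at the limit as well, so the step that the limit leaves unreadable from compound 1 to compound 4 is an estimate with no measured counterpart to lean on. Compound 4 is expected to show about 15000 nM, within a range from 5000 nM to 50000 nM, and a real number under the limit is considered unlikely.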

Compound 4, half-maximal inhibitory concentration: 2080 nM
Compound 4: the middle estimate sits 7.2-fold (0.86 log units) above what was measured; measured number below the stated range.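

The group on the carbonyl carbon can change the result in this assay, which the three earlier compounds could not show, as all of them rested at a limit. Putting 3-hydroxyazetidin-1-yl in place of piperidin-1-yl gives an at least 4.8-fold lower number from compound 1 to compound 4 (0.68 log units; beyond the scatter), and the same group gives an at least 4.8-fold lower number from compound 3 to compound 4 (0.68 log units; beyond the scatter) in place of dimethylamino and an at least 4.8-fold lower number from compound 2 to compound 4 (0.68 log units; beyond the scatter) in place of (2-hydroxyethyl)amino; each step starts from a limit, so its full size cannot be read. A hydroxyl on this group is not enough by itself, since compound 2 also carries one in its (2-hydroxyethyl)amino group and still gives no readable number, while compound 4 does: the limit of > 10000 nM in this assay, at which 3 of the 4 values shown sit.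

The compounds shown do not separate the four-membered ring from its hydroxyl, so it stays open which of the two, or whether the pair together, accounts for the readable number of compound 4. A plain azetidin-1-yl on the same carbonyl carbon would address that question, and a 3-aminoazetidin-1-yl would show whether an amine can take the place of the hydroxyl.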